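A few compounds are considered here, and "the series" means these few. Any claim that something is new, unique, unknown or untested is made for them only; others in the source may bear on it.

Three compounds share one core and differ only in the group on a nitrogen on an aromatic ring. In a functional assay on MCF7 cells (Homo sapiens) for inhibition, read by MTT assay, with a stated time of 72 h (on this read-out higher numbers stand for weaker inhibition and lower numbers for stronger inhibition), compound 1 `N#Cc1c(Nc2cccc(C(F)(F)F)c2)nc(SCc2cn(Cc3ccccc3Cl)nn2)nc1-c1ccccc1` gives 12600 nM. Compound 2 `N#Cc1c(Nc2ccccc2Cl)nc(SCc2cn(Cc3ccccc3Cl)nn2)nc1-c1ccccc1` gives 1950 nM in this assay, and compound 3 `N#Cc1c(Nc2ccc(Cl)cc2)nc(SCc2cn(Cc3ccccc3Cl)nn2)nc1-c1ccccc1` gives 6520 nM. Compound 3 stands second highest of the three: a 3.3-fold higher number from compound 2 to compound 3 (0.52 log units; beyond the scatter), while a 1.9-fold lower number from compound 1 to compound 3 (0.29 log units; within the scatter). Compound 4 `COc1ccccc1Nc1nc(SCc2cn(Cc3ccccc3Cl)nn2)nc(-c2ccccc2)c1C#N` carries the change (2-methoxyphenyl in place of 4-chlorophenyl on a nitrogen on an aromatic ring). Among the compounds with values here, the steps that bear on this are a 6.5-fold lower number from compound 1 to compound 2 (0.81 log units; beyond the scatter) and a 3.3-fold higher number from compound 2 to compound 3 (0.52 log units; beyond the scatter), both showing the 2-chlorophenyl compound with the lowest number. A modest move in the same direction is therefore expected for compound 4, a 2.3-fold lower number from compound 3 to compound 4 (0.37 log units; beyond the scatter). Compound 4 is estimated at 2800 nM, in the range 900 nM to 9000 nM.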

Compound 4, half-maximal inhibitory concentration: 6170 nM
Beside the measured number, compound 4's estimate is 2.2-fold (0.34 log units) below it, and the stated range covers the measured number.
By their numbers in this assay, from the lowest: compound 2; then compounds 4, 3 and 1 (each within the scatter of the next, the first and the last beyond it).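

The 2-chlorophenyl result does not carry over to every 2-substituted ring: methoxy in place of chloro gives a 3.2-fold higher number from compound 2 to compound 4 (0.50 log units; beyond the scatter) in this assay, leaving compound 2 with the lowest number of the four. The other two steps, a 1.1-fold lower number from compound 3 to compound 4 (0.02 log units; within the scatter) and a 2.0-fold lower number from compound 1 to compound 4 (0.31 log units; beyond the scatter), show that the 2-methoxyphenyl group sits close to the 4-chlorophenyl group but only just clear of the 3-(trifluoromethyl)phenyl group. No measurement here explains these differences. Still open, as far as these compounds go, is how a 2-fluorophenyl or 2-methylphenyl group on this nitrogen would read, and so whether the low number depends on chloro itself.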